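The source may report more compounds than this note shows. Statements on the series, on what has been measured and on what is new or still open speak of the compounds shown alone.

Working notes on the series. Compound 1 `O=c1c2ccccc2ccn1[C@@H]1O[C@H](COP(=O)(O)OP(=O)(O)OP(=O)(O)O)[C@@H](O)[C@H]1O` carries the shared core with a hydrogen at the aromatic carbon of interest; in a functional assay for agonist activity at P2Y purinoceptor 2 (Homo sapiens), read by FLIPR (on this read-out lower numbers stand for an effect already at smaller amounts and higher numbers for an effect only at larger amounts of compound), compound 1 gives 31 nM. Compound 2 `COc1ccc2ccn([C@@H]3O[C@H](COP(=O)(O)OP(=O)(O)OP(=O)(O)O)[C@@H](O)[C@H]3O)c(=O)c2c1` carries a methoxy at that carbon; in this assay compound 2 gives 26 nM. The step of a 1.2-fold lower number from compound 1 to compound 2 (0.08 log units; within the scatter) shows that placing methoxy there leaves the read-out essentially unchanged. Among the two numbers so far, compound 2 holds the lowest, with compound 1 as its only neighbour; the two lie within the scatter of each other, so no order between them is claimed.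

Compound 3 `CS(=O)(=O)c1ccc2ccn([C@@H]3O[C@H](COP(=O)(O)OP(=O)(O)OP(=O)(O)O)[C@@H](O)[C@H]3O)c(=O)c2c1` is the next member, differing from compound 2 by methylsulfonyl in place of methoxy on an aromatic carbon. For the measured compounds named here, no measured step covers an exchange of methoxy for methylsulfonyl; the only step that touches this position, from compound 1 to compound 2, was within the scatter. That step indicates the position accepts a substituent without a change beyond the scatter, but it does not inform on the present exchange. For compound 3 in this assay the expectation is a modest shift, estimated as a 2.1-fold higher number from compound 2 to compound 3 (0.33 log units; beyond the scatter). Compound 3 is therefore estimated at 55 nM, with a range from 15 nM to 200 nM.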

Compound 3, half-maximal effective concentration: 650 nM
The estimate for compound 3 lay 12-fold (1.07 log units) below the measured number; the whole stated range lies below it.
By their numbers in this assay, from the lowest: compounds 2 and 1 (each within the scatter of the next); then compound 3.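

In this assay this aromatic carbon no longer looks indifferent to what it carries: methylsulfonyl in place of methoxy gives a 25-fold higher number from compound 2 to compound 3 (1.40 log units; beyond the scatter), and methylsulfonyl in place of hydrogen gives a 21-fold higher number from compound 1 to compound 3 (1.32 log units; beyond the scatter). The earlier step from hydrogen to methoxy stayed within the scatter, whereas both of these steps are large and beyond it, so acceptance of methoxy at this position does not extend to every substituent, and compound 3 stands apart from compound 1 and compound 2. For the compounds shown here, nothing measured so far bears on what lies behind this rise in the number, and the series offers no explanation for it.

The compounds shown leave open whether the rise belongs to methylsulfonyl as a whole or to its sulfur, which a methylthio group or a sulfonamide at the same carbon would help to separate. From the compounds shown here alone, it is also open whether an amine, a carboxylic acid or a longer chain such as ethoxy would stay with hydrogen and methoxy or move with methylsulfonyl.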